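A few compounds are considered here, and "the series" means these few. Any claim that something is new, unique, unknown or untested is made for them only; others in the source may bear on it.

Of the compounds shown here, three built on a shared core have been tested in a functional assay on HeLa cells (Homo sapiens) for cytotoxicity, read by MTT assay, with a stated time of 48 h; on this read-out lower numbers stand for stronger inhibition and higher numbers for weaker inhibition. Compound 1 `COc1ccc(-c2cc(C(=O)Nc3nc4ccc(Cl)cc4s3)nc3cc(-c4ccccc4)nn23)cc1OC` gives 9120 nM. Compound 2 `COc1ccc(-c2cc(C(=O)Nc3nc4ccc(F)cc4s3)nc3cc(-c4ccccc4)nn23)cc1OC` gives 8310 nM. Compound 3 `COc1cc(-c2cc(C(=O)Nc3nc4ccc(F)cc4s3)nc3cc(-c4ccccc4)nn23)cc(OC)c1OC` gives 25100 nM. Compound 2 has the lowest of the three numbers, but its distance from compound 1 is within the scatter: a 1.1-fold lower number from compound 1 to compound 2 (0.04 log units; within the scatter). The change to compound 3 is larger and lies beyond the scatter: a 3.0-fold higher number from compound 2 to compound 3 (0.48 log units; beyond the scatter).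

Compound 4 `COc1ccc2nc(NC(=O)c3cc(-c4ccc(OC)c(OC)c4)n4nc(-c5ccccc5)cc4n3)sc2c1` has not yet been measured. It differs from compound 2 by methoxy in place of fluoro on an aromatic carbon. Neither measured step is a close match. The step from compound 1 to compound 2 exchanges one halogen for another at this same position and stays within the scatter, which suggests the position tolerates a change of substituent. The step from compound 2 to compound 3 brings in a methoxy group, but on a different ring, and costs a modest amount of activity. Because of a 3.0-fold higher number from compound 2 to compound 3 (0.48 log units; beyond the scatter), some loss is considered plausible, while a 1.1-fold lower number from compound 1 to compound 2 (0.04 log units; within the scatter) argues that a change on this ring may be small. The expected step is therefore estimated as a 1.4-fold higher number from compound 2 to compound 4 (0.16 log units; within the scatter), toward a somewhat higher number. Compound 4 is expected to give 12000 nM in this assay, with a range from 5000 nM to 30000 nM.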

Compound 4, half-maximal inhibitory concentration: 11000 nM
Beside the measured number, compound 4's estimate is 1.1-fold (0.04 log units) above it, within the range that was stated.
By their numbers in this assay, from the lowest: compounds 2, 1 and 4 (each within the scatter of the next); then compound 3.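

Replacing fluoro with methoxy on this aromatic carbon gives a 1.3-fold higher number from compound 2 to compound 4 (0.12 log units; within the scatter) in this assay, and replacing chloro with methoxy gives a 1.2-fold higher number from compound 1 to compound 4 (0.08 log units; within the scatter). The earlier compounds had shown only that one halogen could replace another here; these steps extend that tolerance to a non-halogen group with two heavy atoms and one hydrogen-bond acceptor, so fluoro, chloro and methoxy cannot be told apart at this position, whereas the added methoxy on the other ring gives a 3.0-fold higher number from compound 2 to compound 3 (0.48 log units; beyond the scatter) and lies beyond the scatter. No supporting measurement is available to account for this result.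

The compounds shown leave open whether this tolerance extends to groups of a different kind on the same carbon, such as an amine, a carboxylic acid or a longer chain like butoxy, or whether plain hydrogen there would read the same. They also leave open whether methoxy at this position would read alike when paired with the other ring of compound 3, since the comparison here rests on a single substitution pattern on that ring.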